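Notes on the amide-nitrogen substituent in this series

A few compounds are considered here, and "the series" means these few. Any claim that something is new, unique, unknown or untested is made for them only; others in the source may bear on it.

Of the compounds shown here, three with a shared core have been measured in an assay on membranes from Sf9 cells for displacement of a labelled ligand from histamine H2 receptor (Homo sapiens), read by scintillation counting, with a stated time of 60 min; a lower number here means a stronger inhibitor, a higher number a weaker inhibitor. Compound 1 `Cc1nc(N)sc1CCCN/C(N)=N/C(=O)NC(C)c1cccc(F)c1` gives 2.04 nM, compound 2 `Cc1nc(N)sc1CCCN/C(N)=N/C(=O)NC(C)c1ccc(Br)cc1` gives 30.2 nM, and compound 3 `CCCCCCNC(=O)/N=C(\N)NCCCc1sc(N)nc1C` gives 28.8 nM. Compound 3 therefore holds the second highest number of the three, sitting within the scatter of compound 2 and well apart from compound 1. Among the measured compounds shown here, the one step between measured compounds is a 15-fold higher number from compound 1 to compound 2 (1.17 log units; beyond the scatter), which shows how much the group on this branched carbon can matter.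

Compound 4 `Cc1nc(N)sc1CCCN/C(N)=N/C(=O)NC(C)c1cccs1` differs from compound 3 by 1-(thiophen-2-yl)ethyl in place of hexyl on an amide-type nitrogen. For the measured compounds named here, no measured step covers this exact change; the closest guide is that both compound 1 and compound 2 carry a 1-arylethyl group on the amide-type nitrogen, and compound 1 gives 2.04 nM while compound 2 gives 30.2 nM, bracketing compound 3 from below. A modest move toward a lower number is therefore expected for compound 4 in this assay, as a 3.6-fold lower number from compound 3 to compound 4 (0.56 log units; beyond the scatter), with wide uncertainty. The estimate for compound 4 is 8 nM, between 2 nM and 35 nM.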

Compound 4, inhibition constant: 63.1 nM
Compound 4: middle estimate off by 7.9-fold (0.90 log units), on the low side; the measured number lies above the stated range.
By their numbers in this assay, from the lowest: compound 1; then compounds 3 and 2 (each within the scatter of the next); then compound 4.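

In this assay, a ring-bearing 1-substituted ethyl group on the amide-type nitrogen does not by itself give a low number: thiophen-2-yl in place of 3-fluorophenyl gives a 31-fold higher number from compound 1 to compound 4 (1.49 log units; beyond the scatter), and in place of 4-bromophenyl it gives a 2.1-fold higher number from compound 2 to compound 4 (0.32 log units; beyond the scatter). The open hexyl chain also compares favourably, with a 2.2-fold higher number from compound 3 to compound 4 (0.34 log units; beyond the scatter), so compound 4 has the highest number of the four and the ring on the branched carbon, not its mere presence, tracks the result across these compounds. No supporting measurement bears on the reason for these differences.

As far as these compounds go, it remains open how an unsubstituted phenyl or thiophen-3-yl on the same branched carbon would read in this assay. Also open, from the compounds shown here alone, is whether a straight chain longer or shorter than hexyl would move the number.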